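The source may report more compounds than this note shows. Statements on the series, on what has been measured and on what is new or still open speak of the compounds shown alone.

Among the measured compounds shown here, compound 2 `Cc1nn(-c2nc(-c3ccc(Cl)c(Cl)c3)c(SC(C)C)s2)c(C(=O)O)c1-c1cccnc1` holds the lower of the two numbers so far in a functional assay on BJAB cells (Homo sapiens) for antiproliferative activity, with a stated time of 4 days (a higher number here means that more compound is needed for the effect, a lower number that less compound is needed), namely 12000 nM, though the gap to compound 1 `COc1cccc(-c2c(C)nn(-c3nc(-c4ccc(Cl)c(Cl)c4)c(SC(C)C)s3)c2C(=O)O)c1`, which gives 14000 nM, is within the scatter: the step of a 1.2-fold lower number from compound 1 to compound 2 (0.07 log units; within the scatter). Compound 3 `Cc1cc(C)cc(-c2c(C)nn(-c3nc(-c4ccc(Cl)c(Cl)c4)c(SC(C)C)s3)c2C(=O)O)c1` differs from compound 2 on an aromatic carbon: 3,5-dimethylphenyl in place of pyridin-3-yl on an aromatic carbon. For the measured compounds named here, the only measured step at this position, a 1.2-fold lower number from compound 1 to compound 2 (0.07 log units; within the scatter), was small, so a further swap of the aryl group there is expected to move the number little, if at all. Compound 3 is therefore estimated at 12000 nM, in the range 4000 nM to 36000 nM. The expected step is no change at the digits printed from compound 2 to compound 3 (within the scatter).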

Compound 3, half-maximal effective concentration: 2700 nM
Compound 3: middle estimate off by 4.4-fold (0.65 log units), on the high side; the measured number lies below the stated range.
By their numbers in this assay, from the lowest: compound 3; then compounds 2 and 1 (each within the scatter of the next).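

The aryl group at this position matters more than compound 1 and compound 2 suggested: in this assay there is a 4.4-fold lower number from compound 2 to compound 3 (0.65 log units; beyond the scatter), and likewise a 5.2-fold lower number from compound 1 to compound 3 (0.71 log units; beyond the scatter), both beyond the scatter. So a change here can shift the number, and 3,5-dimethylphenyl is the one aryl group shown that stands apart from the other two. Nothing measured here explains this.

Whether both methyl groups are needed remains open, since no ring with only one is shown. So does the outcome with larger groups on the ring, such as isopropyl, or with an amine there.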